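A Longer Chain Between the Amine and the Ether Oxygen

The source may report more compounds than this note shows. Statements on the series, on what has been measured and on what is new or still open speak of the compounds shown alone.

Three compounds share a propargyl amine joined through a flexible chain to an ether oxygen on an aromatic ring. In an assay on BTI cells for inhibition of Amine oxidase [flavin-containing] B (Homo sapiens), read by fluorescence and Amplex Red, with a stated time of 15 min (on this read-out higher numbers stand for weaker inhibition and lower numbers for stronger inhibition), compound 1 `C#CCN(C)CCCCOc1ccc2c(c1)CCC2=O` gives 366 nM, compound 2 `C#CCN(C)CCCCCCOc1ccc2c(c1)OCC2=O` gives 51.9 nM, and compound 3 `C#CCN(C)CCCCOc1ccc2c(c1)CCCC2=O` gives 72.5 nM. Compound 3 thus stands second highest of the three: its number sits close to that of compound 2, within the scatter, while compound 1 lies clearly higher. Compound 4 `C#CCN(C)CCCCCCOc1ccc2c(c1)CCCC2=O` is not yet measured; it differs from compound 3 in one place: 2-(methyl(propargyl)amino)ethyl in place of methyl(propargyl)amino on a saturated chain carbon, four bonds along the chain from an oxygen on an aromatic ring. Within the data shown here, no measured pair isolates this change, so the data cannot show how chain length alone acts. In this assay the step is expected to be small, likely none beyond the scatter. The expected step of a 1.3-fold lower number from compound 3 to compound 4 (0.12 log units; within the scatter) is modest. Compound 4 is therefore estimated at 55 nM, with a range from 18 nM to 170 nM.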

Compound 4, half-maximal inhibitory concentration: 133 nM
Estimate against measurement, compound 4: 2.4-fold (0.38 log units) below; low and high end bracket the measured number.
By their numbers in this assay, from the lowest: compounds 2, 3 and 4 (each within the scatter of the next, the first and the last beyond it); then compound 1.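

Among these compounds, this is the first pair that isolates chain length: 2-(methyl(propargyl)amino)ethyl in place of methyl(propargyl)amino on a saturated chain carbon, four bonds along the chain from an oxygen on an aromatic ring, gives a 1.8-fold higher number from compound 3 to compound 4 (0.26 log units; within the scatter) in this assay. On this core, then, the added chain length has no effect that can be told from the usual scatter. Nothing at hand offers an explanation for this result.

From the compounds shown here alone, whether a still longer chain would keep inhibition at this level remains open. So does whether the same change would act alike on the cores of compound 1 and compound 2.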